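This account rests on a few compounds, and the source may have more. Where it says the series, first, only, none or still open, it means among the compounds named here.

Measured in a functional assay on MCF7 cells (Homo sapiens) for antiproliferative activity, read by MTT assay, with a stated time of 72 h; on this read-out lower numbers stand for stronger inhibition and higher numbers for weaker inhibition:
- Compound 1 `COc1cc(/C=C/c2ccc(C3=C(c4ccc(O)cc4)C4CC(S(=O)(=O)Oc5ccc(Br)cc5)C3O4)cc2)cc(OC)c1` gives > 100000 nM as a limit
- Compound 2 `O=S(=O)(Oc1ccccc1)C1CC2OC1C(c1ccc(/C=C/c3cc(O)cc(O)c3)cc1)=C2c1ccc(O)cc1` gives 20100 nM as a number
- Compound 3 `O=S(=O)(Oc1ccccc1Cl)C1CC2OC1C(c1ccc(/C=C/c3cc(O)cc(O)c3)cc1)=C2c1ccc(O)cc1` gives 40400 nM as a number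

For compound 1 there is only the limit of > 100000 nM in this assay, at which 1 of the 3 values shown sits, and no number. Compound 3 has one numeric neighbour, compound 2, and the measured step of a 2.0-fold higher number from compound 2 to compound 3 (0.30 log units; within the scatter) places the two within the scatter of each other.

The next compound is compound 4 `O=S(=O)(Oc1cccc(C(F)(F)F)c1)C1CC2OC1C(c1ccc(/C=C/c3cc(O)cc(O)c3)cc1)=C2c1ccc(O)cc1`, and the change leading to it is 3-(trifluoromethyl)phenyl in place of 2-chlorophenyl on an oxygen on the same sulfonyl-bound oxygen, with 3-(trifluoromethyl)phenyl in place of 2-chlorophenyl. Within the data shown here, only one measured step bears on this change, since it too alters the aromatic group at this place: a 2.0-fold higher number from compound 2 to compound 3 (0.30 log units; within the scatter) did not move the value in this assay beyond the scatter. It is a single and small precedent, and the group entering now is a different one. On that basis no step beyond the scatter is expected, and no direction is favoured. The estimated change is a 1.2-fold lower number from compound 3 to compound 4 (0.06 log units; within the scatter) and it stays an expectation only. For compound 4 the expected value is 35000 nM in this assay, with an estimated range from 12000 nM to 100000 nM as its span.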

Compound 4, half-maximal inhibitory concentration: 11500 nM
For compound 4 the middle estimate is 3.0-fold (0.48 log units) above the measured one; measured number below the stated range.
By their numbers in this assay, from the lowest: compounds 4, 2 and 3 (each within the scatter of the next, the first and the last beyond it). At a limit, above all of these: compound 1.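

In this assay, the aromatic group on the oxygen bound to the sulfonyl sulfur now produces a step beyond the scatter, which the earlier pair did not show: 3-(trifluoromethyl)phenyl in place of 2-chlorophenyl gives a 3.5-fold lower number from compound 3 to compound 4 (0.55 log units; beyond the scatter). The change at this place is limited, however, since 3-(trifluoromethyl)phenyl in place of the plain phenyl group gives only a 1.7-fold lower number from compound 2 to compound 4 (0.24 log units; within the scatter), so the plain phenyl group lies within the scatter of both substituted groups, and only the two substituted groups are separated from each other. Nothing measured among these compounds accounts for the step between the two substituted groups.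

The step from compound 3 to compound 4 exchanges chloro for trifluoromethyl and also alters where the substituent stands on the phenyl ring, so the compounds shown leave open which of these two differences carries it. Also open, on these data alone, is how an amine, a carboxylic acid or a methoxy group on this phenyl ring, or a cyclohexyl group on the same oxygen, would read in this assay.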